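A few compounds are considered here, and "the series" means these few. Any claim that something is new, unique, unknown or untested is made for them only; others in the source may bear on it.

Of the compounds shown here, three of a shared core have been measured in an ADME assay on cells (Hepatocyte, Mus musculus) for metabolic stability, with a stated time of 30 min; on this read-out higher numbers stand for a more stable compound and lower numbers for a less stable compound. Compound 1 `Nc1cc(C(F)(F)F)cc2c(=O)cc(N3CCN(CC4CCC(O)CC4)CC3)sc12` gives 60% in this assay. Compound 3 `O=c1cc(N2CCN(CC3CCCCC3)CC2)sc2c(NO)cc(C(F)(F)F)cc12` gives 47.8% in this assay. Compound 2 `CC(=O)NC1CCC(CN2CCN(c3cc(=O)c4cc(C(F)(F)F)cc([N+](=O)[O-])c4s3)CC2)CC1` gives 94.9% in this assay, the highest of the three numbers; the nearest is compound 1, lower by an amount beyond the scatter, and the furthest is compound 3, also beyond the scatter.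

The next compound, compound 4 `O=C(OC1CCC(CN2CCN(c3cc(=O)c4cc(C(F)(F)F)cc([N+](=O)[O-])c4s3)CC2)CC1)c1ccccc1`, departs from compound 2 by one change: benzoyloxy in place of acetamido on a saturated ring carbon. Among the measured compounds shown here, nothing among the measured compounds shows a step of this kind, so the direction has to be judged without precedent.

Because compound 2 gives 94.9%, there is almost no room upward, and a lower number is the more likely outcome. Compound 4 is expected to give 60% in this assay, with a range from 25% to 90%. This expected step, a number 34.9 percentage points lower from compound 2 to compound 4 (beyond the scatter), is estimated to fall beyond the scatter, in the direction of a less stable compound.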

Compound 4, percent of the compound remaining: 68.1%
For compound 4 the middle estimate is 8.1 percentage points below the measured one; the measured number falls inside the stated range.
By their numbers in this assay, from the lowest: compound 3; then compounds 1 and 4 (each within the scatter of the next); then compound 2.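

Among the compounds shown here, this is the first pair among the compounds that differs in one place only, so it gives the first direct reading of what the group on this saturated ring carbon can do. In this assay the change from acetamido to benzoyloxy comes with a number 26.8 percentage points lower from compound 2 to compound 4 (beyond the scatter) and so shows that the read-out responds to this group even with the rest of the molecule held constant. Nothing measured here says what lies behind this step.

Since benzoyloxy differs from acetamido in both its linking atoms and its end group, this single pair cannot separate the two parts of the change. Still open, as far as these compounds go, is how a benzamido group, an amine or a carboxylic acid on the same ring carbon would read on the core of compound 2.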